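A few compounds are considered here, and "the series" means these few. Any claim that something is new, unique, unknown or untested is made for them only; others in the source may bear on it.

Working notes on the series. Compound 1 `COc1ccc(-c2nc3cc(C(F)(F)F)ccc3[nH]2)cc1` and compound 2 `O=C(CN1CCCC1)Nc1ccc(-c2nc3ccccc3[nH]2)cc1` share one core. In an ADME assay on MDBK cells (Bos taurus) for cytotoxicity, read by MTT assay, with a stated time of 96 h (a lower number here means that less compound is tolerated, a higher number that more compound is tolerated), compound 1 gives only a limit, > 100000 nM; this is the limit of > 100000 nM in this assay, at which 1 of the 2 values shown sits. In this assay compound 2 gives 70000 nM, the only number shown. Compound 3 `CCC(=O)Nc1ccc(-c2nc3ccccc3[nH]2)cc1` has not yet been measured. It differs from compound 2 by methyl in place of pyrrolidin-1-yl on a saturated chain carbon bound to a carbonyl carbon. Among the measured compounds shown here, no measured step between compounds covers this change. In this assay the step is expected as a 1.3-fold higher number from compound 2 to compound 3 (0.11 log units; within the scatter), not beyond the usual scatter. Compound 3 is therefore estimated at 90000 nM, within a range from 40000 nM to 200000 nM.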

Compound 3, half-maximal cytotoxic concentration: > 100000 nM
Compound 3 gave a limit, no number; the forecaster's own chance of this, stated with the estimate: 40%; middle value at least 1.1-fold (0.04 log units) from the limit.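

In this assay, methyl in place of pyrrolidin-1-yl on a saturated chain carbon bound to a carbonyl carbon gives an at least 1.4-fold higher number from compound 2 to compound 3 (0.15 log units; that floor lies within the scatter). On these data alone, this floor does not separate the two compounds, so the change shows no tolerance lost on removing the ring, and its true size stays unknown. The step remains only a floor because compound 3 reads as a limit: the limit of > 100000 nM in this assay, at which 2 of the 3 values shown sit.

The compounds shown leave open how a primary amine, a carboxylic acid or a longer chain at this position would read in this assay.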